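This account rests on a few compounds, and the source may have more. Where it says the series, first, only, none or still open, it means among the compounds named here.

Measured compounds, all in a functional assay on PC-3 cells (Homo sapiens) for cytotoxicity, read by sulforhodamine B assay, with a stated time of 48 h, tested at 0.01 uM; a lower number here means a stronger effect, a higher number a weaker effect of the compound at the concentration tested:
compound 1, `COc1ccc(-c2cc(/C=C/C(=O)c3ccc(OC)c(OC)c3)[nH]n2)cc1`, gives 95%
compound 2, `COc1cc(-c2cc(/C=C/C(=O)c3ccc(Cl)c(Cl)c3)[nH]n2)cc(OC)c1OC`, gives 95%
compound 3, `COc1ccc(-c2cc(/C=C/C(=O)c3ccc(N)cc3)[nH]n2)cc1OC`, gives 95%

Compound 2 stands level with compound 1 and compound 3 at the digits reported; the three values lie within the scatter of one another, so no order among them can be read from these numbers. Among the measured compounds shown here, the series as measured gives no step between compounds that differ in a single place, so nothing about the size of any single change has been observed yet.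

Compound 4, `COc1ccc(C(=O)/C=C/c2cc(-c3cc(OC)c(OC)c(OC)c3)n[nH]2)cc1OC`, has not been measured in this assay. It is taken as a step from compound 2. The change is 3,4-dimethoxyphenyl in place of 3,4-dichlorophenyl on a carbonyl carbon.

Since every measured compound, whichever aryl group sits on the carbonyl carbon or on the shared core, gives the same read-out within scatter in this assay, the expectation for compound 4 is no step beyond the scatter, in either direction. The estimated step from compound 2 is no change at the digits printed from compound 2 to compound 4 (within the scatter), essentially none. Compound 4 is expected to give about 95% in this assay, with a range from 85% to 100%.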

Compound 4, a percentage reported as activity, at one concentration (the size of the read-out at that concentration, not a potency): 96%
Beside the measured number, compound 4's estimate is 1 percentage points below it, within the range that was stated.
By their numbers in this assay, from the lowest: compounds 1, 2, 3 and 4 (each within the scatter of the next).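

In this assay, 3,4-dimethoxyphenyl in place of 3,4-dichlorophenyl on a carbonyl carbon reads as a number 1 percentage points higher from compound 2 to compound 4 (within the scatter), the first observation in this series of a difference at a single place. The entering group has 2 hydrogen-bond acceptors and the leaving group 0, and it brings oxygen where the other brought chlorine, yet this exchange gives no step beyond the scatter at the one concentration tested, with the rest of compound 2 held constant. No available measurement bears on why the read-out stays within the scatter for this exchange.

Because the exchange was read at only one concentration and on only one background, these compounds leave open whether it would also stay within the scatter at another concentration or with a different group on the other side of the shared core. They also leave open whether a group of another kind on the carbonyl carbon, such as a carboxylic acid or a cyclohexyl ring in place of the aromatic ring, would give a step beyond the scatter.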